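The source may report more compounds than this note shows. Statements on the series, on what has been measured and on what is new or still open speak of the compounds shown alone.

Measured compounds in the series:

compound 1, `O=C(Nc1cc(Oc2ccc(Nc3nccc4[nH]cc(-c5ccc(F)cc5)c(=O)c34)cc2F)ccn1)C1CC1`, 81.8%
compound 2, `CCCC(=O)Nc1cc(Oc2ccc(Nc3nccc4[nH]cc(-c5ccc(F)cc5)c(=O)c34)cc2F)ccn1`, 64.6%

Both were read in a functional assay on MKN-45 cells (Homo sapiens) for antiproliferative activity, read by MTT assay, with a stated time of 72 h, tested at 10 uM; a lower number here means less inhibition, a higher number more inhibition at the concentration tested (going by the name of the read-out). In this assay compound 1 gives 81.8% and compound 2 gives 64.6%. Among the compounds with values here, the one step within the measured pair is a number 17.2 percentage points lower from compound 1 to compound 2 (beyond the scatter), so compound 2 stands at the lower of the two numbers, with compound 1 the only neighbour for comparison.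

Compound 3, `O=C(CO)Nc1cc(Oc2ccc(Nc3nccc4[nH]cc(-c5ccc(F)cc5)c(=O)c34)cc2F)ccn1`, has not yet been measured. It differs from compound 2 by hydroxy in place of ethyl on a saturated chain carbon bound to a carbonyl carbon.

Within the data shown here, no measured step bears directly on this change: the only step in hand swaps propyl for cyclopropyl on the carbonyl carbon, and it is the step of a number 17.2 percentage points lower from compound 1 to compound 2 (beyond the scatter), of modest size. Nothing in the two values indicates how a hydroxy in place of ethyl on the chain carbon bound to the carbonyl will read, so the expectation rests on compound 2 alone, with a wide margin. The step from compound 2 to compound 3 is estimated as a number 2.6 percentage points lower from compound 2 to compound 3 (within the scatter), that is, no change beyond the scatter in either direction. Compound 3 is therefore expected to give about 62% in this assay, within 40% to 82%.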

Compound 3, a percentage reported as inhibition, at one concentration (the size of the read-out at that concentration, not a potency): 63%
Compound 3: the middle estimate sits 1 percentage points below what was measured; low and high end bracket the measured number.
By their numbers in this assay, from the lowest: compounds 3 and 2 (each within the scatter of the next); then compound 1.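

In this assay, the step of a number 1.6 percentage points lower from compound 2 to compound 3 (within the scatter) comes with hydroxy in place of ethyl on the saturated chain carbon bound to the carbonyl carbon, so this exchange of an ethyl for a hydroxy leaves the read-out unchanged within the scatter, something the earlier pair could not show. Hydroxymethyl in place of cyclopropyl on the carbonyl carbon gives the step of a number 18.8 percentage points lower from compound 1 to compound 3 (beyond the scatter) and points the same way as the propyl exchange, which gave a number 17.2 percentage points lower from compound 1 to compound 2 (beyond the scatter); among these three compounds, both open-chain groups therefore read apart from cyclopropyl, with no compound going against this. No supporting data bear on why the two open-chain groups read alike or why cyclopropyl stands apart.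

The compounds shown leave open whether an amine or a carboxylic acid on the same chain carbon would also read like ethyl and hydroxy, or whether the level number seen here is limited to these two groups. They also leave open how a longer chain, or a cyclobutyl in place of cyclopropyl on the carbonyl carbon, would read against compound 1.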